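Shortening the Amine Chain: From Compound 2 to Compound 3

A few compounds are considered here, and "the series" means these few. Any claim that something is new, unique, unknown or untested is made for them only; others in the source may bear on it.

Measured compounds:
Compound 1 `[O-][n+]1nc(NC2CCCCC2)[n+]([O-])c2ccccc21`: 2500 nM
Compound 2 `CCCCCCCCNc1n[n+]([O-])c2ccccc2[n+]1[O-]`: 7200 nM

Both compounds were tested in a functional assay on HL-60 cells (Homo sapiens) for cytotoxicity, read by MTT assay, with a stated time of 48 h; on this read-out lower numbers stand for stronger inhibition and higher numbers for weaker inhibition. Compound 2 stands at the highest of the two numbers measured; its nearest neighbour is compound 1, whose number is lower by a gap that lies beyond the scatter, so compound 2 is the weaker of the pair in this assay.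

Compound 3 `C=CCNc1n[n+]([O-])c2ccccc2[n+]1[O-]` has not yet been measured. It differs from compound 2 in one place: vinyl in place of heptyl on a saturated chain carbon bound to a nitrogen on an aromatic ring. Going by the values given here, no pair of measured compounds separated by a single change is available, so the size of this step cannot be read from a neighbouring pair. Because the two measured numbers, 2500 nM for compound 1 and 7200 nM for compound 2, sit close together, a modest step is expected, slightly toward stronger inhibition. For compound 3 the expected step is a 1.6-fold lower number from compound 2 to compound 3 (0.20 log units; within the scatter). Compound 3 is therefore estimated at 4500 nM, within a range from 1500 nM to 14000 nM.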

Compound 3, half-maximal inhibitory concentration: 25800 nM
Beside the measured number, compound 3's estimate is 5.7-fold (0.76 log units) below it; the measured number lies above the stated range.
By their numbers in this assay, from the lowest: compound 1; then compound 2; then compound 3.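

In this assay, going by these compounds alone, these steps give the first direct reading of how the group on this nitrogen affects the number: vinyl in place of heptyl on the saturated chain carbon gives a 3.6-fold higher number from compound 2 to compound 3 (0.55 log units; beyond the scatter), and allyl in place of cyclohexyl on the nitrogen gives a 10-fold higher number from compound 1 to compound 3 (1.01 log units; beyond the scatter). Both steps lie beyond the scatter and run the same way, toward weaker inhibition, with the step from the cyclohexyl compound the larger of the two. Nothing available here accounts for either shift.

In the step from heptyl to vinyl, the shorter chain and the double bond enter together, so a saturated propyl group would be needed to tell their contributions apart. As far as these compounds go, a butyl chain, or a hydroxyl or amine at the end of the chain, also remains open.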